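Sulfonate-bridged nucleoside series: amide to methyl ester

This account rests on a few compounds, and the source may have more. Where it says the series, first, only, none or still open, it means among the compounds named here.

Measured so far in a functional assay on MT4 cells (Homo sapiens); a lower number here means that less compound is tolerated, a higher number that more compound is tolerated:
- compound 1 `Cc1cn([C@@H]2O[C@H](CO[Si](C)(C)C(C)(C)C)[C@@]3(OS(=O)(=O)C=C3NCC(N)=O)[C@H]2O[Si](C)(C)C(C)(C)C)c(=O)n(C)c1=O`: 14900 nM
- compound 2 `Cc1cn([C@@H]2O[C@H](CO[Si](C)(C)C(C)(C)C)[C@@]3(OS(=O)(=O)C=C3NCC(=O)C(=O)N3CCC3)[C@H]2O[Si](C)(C)C(C)(C)C)c(=O)n(C)c1=O`: 17400 nM
- compound 3 `Cc1cn([C@@H]2O[C@@H]3COC(=O)[C@]3(OS(C)(=O)=O)[C@H]2O)c(=O)[nH]c1=O`: >= 250000 nM, which is a limit of the assay and not a number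

Compound 1 and compound 2 sit within the scatter of one another, as the change a 1.2-fold higher number from compound 1 to compound 2 (0.07 log units; within the scatter) shows. Compound 3 returns only a limit, namely (the limit of >= 250000 nM in this assay, at which 1 of the 3 values shown sits); nothing more is said of it here.

Compound 4 `COC(=O)CNC1=CS(=O)(=O)O[C@@]12[C@@H](CO[Si](C)(C)C(C)(C)C)O[C@@H](n1cc(C)c(=O)n(C)c1=O)[C@@H]2O[Si](C)(C)C(C)(C)C` is not yet measured. It differs from compound 1 in one place: methoxy in place of amino on a carbonyl carbon. Going by the values given here, the only measured step on the same carbonyl carbon, a 1.2-fold higher number from compound 1 to compound 2 (0.07 log units; within the scatter), stayed within the scatter, and no measured pair shows methoxy in place of amino. On that basis no step beyond the scatter is expected, in either direction, so the estimated change is a 1.0-fold higher number from compound 1 to compound 4 (0.00 log units; within the scatter). Compound 4 is therefore estimated at 15000 nM in this assay, with a range from 7000 nM to 32000 nM.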

Compound 4, half-maximal cytotoxic concentration: 105000 nM
Beside the measured number, compound 4's estimate is 7.0-fold (0.85 log units) below it; the measured number lies above the stated range.
By their numbers in this assay, from the lowest: compounds 1 and 2 (each within the scatter of the next); then compound 4. At a limit, above all of these: compound 3.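

In this assay, the carbonyl carbon of this side chain proves responsive to its substituent, which the earlier pair alone did not show: methoxy in place of amino gives a 7.0-fold higher number from compound 1 to compound 4 (0.85 log units; beyond the scatter), and methoxy in place of (azetidin-1-yl)carbonyl gives a 6.0-fold higher number from compound 2 to compound 4 (0.78 log units; beyond the scatter). Of the three groups tested at this place, amino and (azetidin-1-yl)carbonyl remain within the scatter of each other, and methoxy alone stands apart, so the position tolerates some changes without a shift but not all. Nothing measured here gives a reason for this step.

As far as these compounds go, it remains open whether a carboxylic acid, an ethoxy group or a methylamino group on the same carbonyl carbon would fall with methoxy or with amino. Also open, from the compounds shown here alone, is whether the methoxy step holds on a core carrying free hydroxyl groups in place of the silyl ethers.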